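Tetrafluorophenyl Tail in a Diacid: Permeability Outlook

The compounds below may be only part of what the source reports. "The series", "measured", "known", "first", "only" and "open" are said of these compounds alone.

Measured compounds:
compound 1, `Cc1c(CCCC(=O)O)c2cccc(/C=C/c3ccc(OCCCCc4ccccc4)cc3)c2n1CC(=O)O`, giving 1.3 10^-6 cm/s
compound 2, `O=C(O)CCCn1cc(CC(=O)O)c2c(/C=C/c3ccc(OCCCCOc4ccccc4)cc3)cccc21`, giving 6.9 10^-6 cm/s

In a physicochemical assay for permeability, using PAMPA, with a stated time of 4 h, at pH 6.2, tested at 50 uM (on this read-out lower numbers stand for lower permeability and higher numbers for higher permeability), compound 1 stands at the lower of the two numbers, with 1.3 10^-6 cm/s. For the measured compounds named here, compound 2, a differently built analogue, gives 6.9 10^-6 cm/s, a higher reading that lies beyond the usual scatter; no single-point step links these two compounds, so only the two values themselves can be compared.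

Compound 3, `Cc1c(CCCC(=O)O)c2cccc(/C=C/c3ccc(OCCCCc4cc(F)c(F)c(F)c4F)cc3)c2n1CC(=O)O`, has not yet been measured in this assay. Relative to compound 1 it changes in one place: 2,3,4,5-tetrafluorophenyl in place of phenyl on a saturated chain carbon, four bonds along the chain from an oxygen on an aromatic ring. Going by the values given here, no step between measured compounds shows what this particular change does, so its size is open. The expectation for compound 3 is a modest rise, a 1.8-fold higher number from compound 1 to compound 3 (0.27 log units; within the scatter), which may not clear the scatter. Compound 3 is thus estimated at 2.4 10^-6 cm/s, within a range of 1 10^-6 cm/s to 6 10^-6 cm/s.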

Compound 3, apparent permeability: 1.8 10^-6 cm/s
The estimate for compound 3 lay 1.3-fold (0.12 log units) above the measured number, and the stated range covers the measured number.
By their numbers in this assay, from the lowest: compounds 1 and 3 (each within the scatter of the next); then compound 2.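

In this assay, putting 2,3,4,5-tetrafluorophenyl in place of phenyl on a saturated chain carbon, four bonds along the chain from an oxygen on an aromatic ring, gives a 1.4-fold higher number from compound 1 to compound 3 (0.14 log units; within the scatter) and so leaves compound 1 and compound 3 indistinguishable on this read-out. For the compounds shown here, the earlier compounds offered no step at all, so this pair is the first direct reading of any change at this position, and it shows that the 2,3,4,5-tetrafluorophenyl group can stand there in place of the six-atom phenyl without a difference that clears the scatter. Nothing measured alongside these compounds speaks to the reason for this result.

From the compounds shown here alone, whether an amine, a carboxylic acid or a pyridine ring at the same place would move the number remains open. So does the reading for a longer chain carrying the 2,3,4,5-tetrafluorophenyl group.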